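Swapping a benzylamino arm for a chlorobenzimidazole

The source may report more compounds than this note shows. Statements on the series, on what has been measured and on what is new or still open speak of the compounds shown alone.

Measured compounds:
- Compound 1 `Cc1cc(C)cc(-c2cncc(-c3nc4cc(C(F)(F)F)ccc4[nH]3)c2N2CCC(N)CC2)c1`: 0.014 nM
- Compound 2 `Cc1cc(C)cc(CNc2cncc(-c3cc(C)cc(C)c3)c2N2CCC(N)CC2)c1`: 0.8 nM

In a functional assay on CHO-K1 cells for agonist activity at somatostatin receptor type 2 (Homo sapiens), read by cAMP accumulation, with a stated time of 30 min (a lower number here means that less compound is needed, a higher number that more compound is needed for the effect), compound 1 gives 0.014 nM. Compound 2 stands at the highest of the two numbers, giving 0.8 nM in this assay, and its nearest neighbour, compound 1, lies well beyond the scatter below it. Compound 3 `Cc1cc(C)cc(-c2cncc(-c3nc4cc(Cl)ccc4[nH]3)c2N2CCC(N)CC2)c1` has not yet been measured. It differs from compound 2 in one place: 5-chloro-1H-benzimidazol-2-yl in place of (3,5-dimethylbenzyl)amino on an aromatic carbon. With that change, compound 3 becomes far more like compound 1 than like compound 2. For the measured compounds named here, the only measured number of that kind is the low one: compound 1 gives 0.014 nM. A large step down is therefore expected from compound 2 to compound 3, a 27-fold lower number from compound 2 to compound 3 (1.43 log units; beyond the scatter), well beyond the scatter. For compound 3 the expected value in this assay is 0.03 nM, with a range from 0.008 nM to 0.12 nM.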

Compound 3, half-maximal effective concentration: 0.015 nM
Compound 3: middle estimate off by 2.0-fold (0.30 log units), on the high side, and the stated range covers the measured number.
By their numbers in this assay, from the lowest: compounds 1 and 3 (each within the scatter of the next); then compound 2.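

In this assay, 5-chloro-1H-benzimidazol-2-yl in place of (3,5-dimethylbenzyl)amino on this aromatic carbon, ortho to the 4-aminopiperidin-1-yl group, gives a 53-fold lower number from compound 2 to compound 3 (1.73 log units; beyond the scatter), so the group at this position can shift the number by a large amount. The two groups match in heavy atoms, hydrogen-bond donors and hydrogen-bond acceptors, yet their numbers lie far apart, so those counts alone do not predict the result here. On the benzimidazole, chloro in place of trifluoromethyl gives a 1.1-fold higher number from compound 1 to compound 3 (0.03 log units; within the scatter), so this assay does not separate these two substituents.

Nothing available here says what lies behind the large step. Going by these compounds, it also remains open whether a methoxy group or a nitrile in place of chloro would keep the number this low.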